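Triazole substituent swap in the ascorbate-derived series

This account rests on a few compounds, and the source may have more. Where it says the series, first, only, none or still open, it means among the compounds named here.

Compound 2 `O=C1O[C@H]([C@@H](O)Cn2cc(CNS(=O)(=O)c3ccc(F)cc3)nn2)C(OCc2ccccc2)=C1OCc1ccccc1` is one of three members of this set tested in a functional assay on A549 cells (Homo sapiens) for antiproliferative activity, read by MTT assay, with a stated time of 72 h (a lower number here means a stronger inhibitor, a higher number a weaker inhibitor), where compound 2 gives 22500 nM. This is the lowest of the two numbers shown, but the neighbouring compound 1 `O=C1O[C@H]([C@@H](O)Cn2cc(CNS(=O)(=O)c3ccc(Cl)cc3F)nn2)C(OCc2ccccc2)=C1OCc1ccccc1` gives 39100 nM, and the step of a 1.7-fold lower number from compound 1 to compound 2 (0.24 log units; within the scatter) lies within the scatter, so compound 1 and compound 2 cannot be separated. Compound 3 `O=C1O/C(=C\Cn2cc(-c3cc(C(F)(F)F)cc(C(F)(F)F)c3)nn2)C(OCc2ccccc2)=C1OCc1ccccc1` returns only a limit in this assay, > 100000 nM, so no number is available for it; this is recorded as the limit of > 100000 nM in this assay, at which 1 of the 3 values shown sits.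

Compound 4 `CCCCCc1ccc(-c2cn(C[C@H](O)[C@H]3OC(=O)C(OCc4ccccc4)=C3OCc3ccccc3)nn2)cc1` is not yet measured. It differs from compound 2 by 4-pentylphenyl in place of (((4-fluorophenyl)sulfonyl)amino)methyl on an aromatic carbon. Within the data shown here, no measured step bears on this change: the only step available, from compound 1 to compound 2, alters a substituent on the sulfonyl aryl and stays within the scatter, and compound 3 carries a different core and an aryl group of another kind, so its limit cannot be tied to this replacement. Given that the whole set is weak and one member already sits at the limit, a step of a 2.2-fold higher number from compound 2 to compound 4 (0.35 log units; beyond the scatter) toward a higher number is expected for compound 4, with a real chance that only a limit is reported. The estimate for compound 4 is 50000 nM, in the range 15000 nM to 150000 nM.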

Compound 4, half-maximal inhibitory concentration: 6220 nM
Beside the measured number, compound 4's estimate is 8.0-fold (0.91 log units) above it; measured number outside the range, below it.
By their numbers in this assay, from the lowest: compound 4; then compounds 2 and 1 (each within the scatter of the next). At a limit, above all of these: compound 3.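

In this assay, among these compounds, putting 4-pentylphenyl in place of (((4-fluorophenyl)sulfonyl)amino)methyl gives a 3.6-fold lower number from compound 2 to compound 4 (0.56 log units; beyond the scatter), the first step in this set that lies beyond the scatter. The number therefore responds to the group on this aromatic carbon of the five-membered aromatic ring with 3 nitrogen, whereas the substituent change on the sulfonyl aryl left compound 1 and compound 2 inseparable, and the sulfonyl amino unit with its hydrogen-bond donor and acceptors is not required to reach the value of compound 4. Nothing measured here gives a reason for this step.

On these data alone, this single change replaces the linker, the aryl attachment and the alkyl chain together, so it remains open which of these carries the step, and a plain phenyl, a butyl or octyl chain in place of pentyl, or an amine at the end of the chain would separate them. Compound 3 remains a limit at > 100000 nM and differs from compound 4 in more than one place, so it does not show how other aryl groups behave on the shared core.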